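Swapping acetoxy for hydroxy on compound 3

This account rests on a few compounds, and the source may have more. Where it says the series, first, only, none or still open, it means among the compounds named here.

Of the compounds shown here, three have been measured so far in a functional assay on cells (Homo sapiens) for inhibition; on this read-out lower numbers stand for stronger inhibition and higher numbers for weaker inhibition. Compound 3 (`CC(=O)ON(/C=C\C(=O)c1ccc(Cl)cc1)Cc1ccccc1`) gives > 10000 nM, which is a limit of the assay and not a number. Compound 3 therefore stands at the limit of > 10000 nM in this assay, at which 2 of the 3 values shown sit. Compound 1 (`CN(O)/C=C\C(=O)c1ccc(Cl)cc1`) gives > 10000 nM, which is also a limit. Among the measured compounds shown here, compound 2 (`O=C(/C=C\N(O)Cc1ccccc1)c1ccc([N+](=O)[O-])cc1`) is the only one with a true number, at 1700 nM.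

Compound 4 (`O=C(/C=C\N(O)Cc1ccccc1)c1ccc(Cl)cc1`) is made from compound 3 by a single change: hydrogen in place of acetyl on an oxygen, so that acetoxy becomes hydroxy (hydrogen in place of acetyl on an oxygen). For the measured compounds named here, no measured pair shows this change on its own, so any forecast is rough. Compound 2 carries hydroxy and gives 1700 nM, which suggests that the change could bring measurable inhibition. Compound 1 goes against that hope, as it carries hydroxy too and gives > 10000 nM. A sizeable step towards stronger inhibition in this assay is therefore expected, though with low confidence. The expected step is an at least 3.3-fold lower number from compound 3 to compound 4 (0.52 log units; beyond the scatter). The estimated value for compound 4 is 3000 nM, with an expected range from 800 nM to 10000 nM.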

Compound 4, half-maximal inhibitory concentration: 2100 nM
For compound 4 the middle estimate is 1.4-fold (0.15 log units) above the measured one; measured number inside the range.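

Swapping acetoxy for hydroxy on this oxygen brings compound 4 into the measurable range of this assay, with an at least 4.7-fold lower number from compound 3 to compound 4 (0.67 log units; beyond the scatter), and the hydroxy does not do this alone, since adding phenyl on the saturated chain carbon bound to the amine nitrogen gives an at least 4.7-fold lower number from compound 1 to compound 4 (0.67 log units; beyond the scatter). So hydroxy and that phenyl are both present in the compounds with a true number, whereas compound 1 lacks the phenyl and compound 3 lacks the hydroxy. Chloro and nitro on the aromatic carbon cannot be told apart here, with a 1.2-fold higher number from compound 2 to compound 4 (0.09 log units; within the scatter). The two larger steps are lower bounds only, and their true size stays unknown, because each starts from a compound whose value is a limit and not a number: the limit of > 10000 nM in this assay, at which 2 of the 4 values shown sit.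

The compounds shown leave open how a methoxy group in place of hydroxy would compare, and whether a longer chain between the amine nitrogen and the phenyl would keep the inhibition. They also leave open whether an amine or a carboxylic acid in place of chloro on the aromatic carbon would read like chloro and nitro.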